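Swapping sec-butyl for carbamoylmethyl: a small expected step

The source may hold more compounds than are shown below. What is called first, only, known or untested is meant among the compounds shown, and "the series" means these compounds.

Within the data shown here, in a functional assay on CCRF-CEM cells (Homo sapiens) for inhibition, with a stated time of 72 h (on this read-out higher numbers stand for weaker inhibition and lower numbers for stronger inhibition), compound 1 (`CC[C@H](C)[C@H](NC(=O)OC(C)(C)C)C(=O)N(Cc1ccccc1)C1(C(=O)NCc2ccccc2)CCN(Cc2ccccc2)CC1`) gives 7100 nM and sits level with the only other measured compound. Compound 2 (`CCC(C)N(C(=O)[C@H](CC(=O)OC)NC(=O)OCc1ccccc1)C1(C(=O)NCc2ccccc2)CCN(Cc2ccccc2)CC1`) gives 4500 nM there, and these two values lie within the usual scatter of each other, so neither can be ranked over the other.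

Among the measured compounds shown here, compound 3 (`CC(C)(C)OC(=O)N[C@@H](CC(N)=O)C(=O)N(Cc1ccccc1)C1(C(=O)NCc2ccccc2)CCN(Cc2ccccc2)CC1`) has no measurement yet. It keeps the core of compound 1 and carries carbamoylmethyl in place of sec-butyl on a saturated chain carbon bound to an amide-type nitrogen and a carbonyl carbon.

For the measured compounds named here, no measured pair here differs in just one place, so nothing shows directly what this swap does. Going by the values given here, the only anchors are compound 1 at 7100 nM and compound 2 at 4500 nM on this read-out. In this assay no step beyond the scatter is expected, with perhaps a slight drift toward weaker inhibition. An estimated 1.3-fold higher number from compound 1 to compound 3 (0.10 log units; within the scatter) would fit that view. For compound 3 the estimated value is 9000 nM with an expected range from 3000 nM to 25000 nM once it is measured.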

Compound 3, half-maximal inhibitory concentration: 26000 nM
The estimate for compound 3 lay 2.9-fold (0.46 log units) below the measured number; measured number outside the range, above it.
By their numbers in this assay, from the lowest: compounds 2 and 1 (each within the scatter of the next); then compound 3.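

This position does not tolerate every group equally: in this assay, carbamoylmethyl in place of sec-butyl on a saturated chain carbon bound to an amide-type nitrogen and a carbonyl carbon gives a 3.7-fold higher number from compound 1 to compound 3 (0.56 log units; beyond the scatter), a modest step toward weaker inhibition but one that clears the usual scatter. Among these compounds, it is the first step in this set that can be read at a single place, and the rest of the molecule stays the same. The two groups hold 4 heavy atoms each, so the size of the swapped group by that count does not change, while an all-carbon group with no hydrogen-bond donor or acceptor gives way to one with nitrogen, oxygen, a hydrogen-bond donor and a hydrogen-bond acceptor; nothing available here bears on why the number rises.

Among the compounds shown here, with only this one swap to read, it remains unknown which difference between the two groups matters. As far as these compounds go, a carboxylic acid, an amine or a longer hydrocarbon chain at the same place could help separate those differences, and whether the step would hold with other groups elsewhere on the core of compound 1 also remains open.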